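The source may hold more compounds than are shown below. What is called first, only, known or untested is meant among the compounds shown, and "the series" means these compounds.

Measured so far:
compound 1, `COc1ccc(-c2nnc(-n3[se]c4ccccc4c3=O)s2)cc1`, 16500 nM;
compound 2, `Cc1cccc(-c2nnc(-n3[se]c4ccccc4c3=O)s2)c1`, 17800 nM;
compound 3, `O=c1c2ccccc2[se]n1-c1nnc(-c2ccccc2Br)s1`, 27400 nM.

All three numbers come from a functional assay on SSMC-7721 cells (Homo sapiens) for antiproliferative activity, read by CCK-8 assay, with a stated time of 48 h; on this read-out lower numbers stand for stronger inhibition and higher numbers for weaker inhibition. Compound 3 sits within the scatter of both compound 2 and compound 1, so the three cannot be told apart on these data. Compound 4, `Cc1ccc(-c2nnc(-n3[se]c4ccccc4c3=O)s2)cc1`, differs from compound 3 by 4-methylphenyl in place of 2-bromophenyl on an aromatic carbon. Among the compounds with values here, the only measured step that touches the same position is a 1.5-fold higher number from compound 2 to compound 3 (0.19 log units; within the scatter), an exchange of one aryl group for another that stayed within the scatter. On that basis no shift beyond the scatter is expected in this assay, and compound 4 is estimated at 18000 nM, with a range from 9000 nM to 36000 nM, the expected step being a 1.5-fold lower number from compound 3 to compound 4 (0.18 log units; within the scatter).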

Compound 4, half-maximal inhibitory concentration: 16600 nM
Estimate against measurement, compound 4: 1.1-fold (0.04 log units) above, within the range that was stated.
By their numbers in this assay, from the lowest: compounds 1, 4, 2 and 3 (each within the scatter of the next).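

In this assay, three further exchanges on the aryl group leave the number within the scatter: 4-methylphenyl for 2-bromophenyl gives a 1.7-fold lower number from compound 3 to compound 4 (0.22 log units; within the scatter), 4-methylphenyl for 3-methylphenyl gives a 1.1-fold lower number from compound 2 to compound 4 (0.03 log units; within the scatter), and methyl for methoxy gives a 1.0-fold higher number from compound 1 to compound 4 (0.00 log units; within the scatter). Neither the place of the methyl on the phenyl ring nor the choice of methyl, methoxy or bromine separates these compounds here. No evidence on the reason for this is available. The compounds shown leave open whether a phenyl ring carrying an amine or a carboxylic acid would move the number beyond the scatter.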